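The compounds below may be only part of what the source reports. "The series", "measured", "known", "first", "only" and "open" are said of these compounds alone.

Compound 1 `O=C(COc1c(F)cc(C(=O)c2ccc(F)cc2)cc1Cl)NNC(=O)c1ccc(=O)oc1`: 89800 nM
Compound 2 `Cc1ccc(C(=O)c2cc(F)c(OCC(=O)NNC(=O)c3ccc(=O)oc3)c(Cl)c2)cc1`: 32100 nM

Both values come from an ADME assay on NIH3T3 cells (Mus musculus) for cytotoxicity, read by LDH release, with a stated time of 48 h (on this read-out lower numbers stand for stronger inhibition and higher numbers for weaker inhibition), where compound 1 holds the higher of the two numbers. Compound 3 `Cn1cnc(C(=O)NNC(=O)COc2c(F)cc(C(=O)c3ccc(F)cc3)cc2Cl)c1` keeps the core of compound 1 and changes one group on a carbonyl carbon: a group of 6 heavy atoms (4 carbon, 2 nitrogen; one five-membered aromatic ring with 2 hetero atoms) in place of a group of 7 heavy atoms (5 carbon, 2 oxygen; one six-membered aromatic ring with 1 hetero atom), on a carbonyl carbon. Going by the values given here, the only measured step, a 2.8-fold lower number from compound 1 to compound 2 (0.45 log units; beyond the scatter), is a change on an aromatic carbon, so it bears on this change only indirectly. Among the compounds with values here, no measured compound carries the entering group. Within the data shown here, a modest move toward a lower number is expected, no larger than that step. The expected change is a 1.6-fold lower number from compound 1 to compound 3 (0.21 log units; within the scatter). For compound 3 the estimate is 55000 nM, with an expected range of 20000 nM to 130000 nM.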

Compound 3, half-maximal inhibitory concentration: 94400 nM
Beside the measured number, compound 3's estimate is 1.7-fold (0.23 log units) below it, and the stated range covers the measured number.
By their numbers in this assay, from the lowest: compound 2; then compounds 1 and 3 (each within the scatter of the next).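

In this assay the exchange on the carbonyl carbon, 1-methyl-1H-imidazol-4-yl for the six-membered aromatic ring, gives a 1.1-fold higher number from compound 1 to compound 3 (0.02 log units; within the scatter) and so stays within the scatter. Going by these compounds alone, this is the first reading at this position, and the five-membered ring with 2 hetero atoms leaves the number where compound 1 has it, unlike the methyl for fluoro step on the aromatic carbon. Nothing available explains this result.

Open, from the compounds shown here alone, is whether an amine or a carboxylic acid on this carbonyl carbon would move the number. Also open, going by these compounds, is whether the methyl for fluoro step holds with 1-methyl-1H-imidazol-4-yl in place.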